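The source may hold more compounds than are shown below. What is called first, only, known or untested is meant among the compounds shown, and "the series" means these compounds.

Compound 1 `CCCCCCCCc1c(O)cc(C)oc1=O` and compound 3 `CCCCCCCCCCc1c(O)cc(C)oc1=O` share a core and differ by ethyl in place of hydrogen on a saturated chain carbon, eight bonds along the chain from an aromatic carbon. In an ADME assay on L929 cells (Mus musculus, culture collection number NCTC 929) for cytotoxicity, read by MTT assay, with a stated time of 72 h (a higher number here means a weaker inhibitor, a lower number a stronger inhibitor), compound 1 gives 145000 nM, while compound 3 gives 56000 nM, so the change made a 2.6-fold lower number from compound 1 to compound 3 (0.41 log units; beyond the scatter). Compound 2 `CCCCCCCCCCCCCC(=O)c1c(O)cc(C)oc1=O` carries a different core, and the difference between the two cores is not broken down here. In this assay compound 2 reaches only a limit, > 200000 nM, which is the limit of > 200000 nM in this assay, at which 1 of the 3 values shown sits. Compound 4 `CCCCCCCCCCCCCCCC(=O)c1c(O)cc(C)oc1=O` is the not yet measured partner of compound 2, made by ethyl in place of hydrogen on a saturated chain carbon, ten or more bonds along the chain from a carbonyl carbon; this is the same kind of change as that from compound 1 to compound 3, though the new ethyl sits at a different place along the chain in the two pairs, as the two differences show. A step of an at least 1.3-fold lower number from compound 2 to compound 4 (0.12 log units; that floor lies within the scatter) is expected for compound 4, resting on the step of a 2.6-fold lower number from compound 1 to compound 3 (0.41 log units; beyond the scatter) seen for the same kind of change. Compound 4 is therefore estimated at 150000 nM, between 60000 nM and 300000 nM.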

Compound 4, half-maximal inhibitory concentration: 165000 nM
Beside the measured number, compound 4's estimate is 1.1-fold (0.04 log units) below it; the measured number falls inside the stated range.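

Ethyl in place of hydrogen, carried to the core of compound 2, gives an at least 1.2-fold lower number from compound 2 to compound 4 (0.08 log units; that floor lies within the scatter) in this assay. Compound 2 stands at a limit of the assay, > 200000 nM, and that is not a number. The step therefore fits the change carrying over from one core to the other, but it does not show that the change carries over, nor that its size is the same on both cores: the same change on two cores in this assay, a 2.6-fold lower number (0.41 log units; beyond the scatter) from compound 1 to compound 3 and an at least 1.2-fold lower number (0.08 log units; that floor lies within the scatter) from compound 2 to compound 4; the limit leaves it open whether they differ

The compounds shown leave open what a longer chain would do on either core. They also leave open whether a chain bearing an amine or a carboxylic acid would follow the same course.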